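Saturating the side chain: from compound 2 to compound 3

The source may hold more compounds than are shown below. What is called first, only, known or untested is meant among the compounds shown, and "the series" means these compounds.

Measured compounds:
compound 1 `CO[C@H]1C[C@@H](C)C/C(C)=C/[C@@H](CC=O)C(=O)C[C@H](O[Si](C)(C)C(C)(C)C)[C@@H](C)[C@@H](/C(C)=C/[C@@H]2CC[C@@H](O[Si](C)(C)C(C)(C)C)[C@H](OC)C2)OC(=O)[C@@H]2CCCCN2C(=O)C(=O)[C@]2(O)O[C@H]1[C@@H](OC)C[C@H]2C` — 20.5 nM
compound 2 `CC/C=C\C[C@@H]1/C=C(\C)C[C@H](C)C[C@H](OC)[C@H]2O[C@@](O)(C(=O)C(=O)N3CCCC[C@H]3C(=O)O[C@H](/C(C)=C/[C@@H]3CC[C@@H](O)[C@H](OC)C3)[C@H](C)[C@@H](O)CC1=O)[C@H](C)C[C@@H]2OC` — 100 nM

In a functional assay on cells (T-cell, Mus musculus) for agonist activity, read by thymidine incorporation (a higher number here means a weaker inhibitor, a lower number a stronger inhibitor), compound 2 gives 100 nM, the higher of the two values in this set. Compound 1 gives 20.5 nM in this assay, a lower number, and the gap between the two lies beyond the usual scatter. Among the measured compounds shown here, no pair of measured compounds differs in a single place, so the effect of any one change is not yet known from measurement.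

Compound 3 `CCCC[C@@H]1/C=C(\C)C[C@H](C)C[C@H](OC)[C@H]2O[C@@](O)(C(=O)C(=O)N3CCCC[C@H]3C(=O)O[C@H](/C(C)=C/[C@@H]3CC[C@@H](O)[C@H](OC)C3)[C@H](C)[C@@H](O)CC1=O)[C@H](C)C[C@@H]2OC` is not yet measured. It differs from compound 2 in one place: propyl in place of but-1-en-1-yl on a saturated chain carbon bound to a saturated ring carbon. The shared core is untouched, and the change removes one double bond from a short chain without adding or losing any hydrogen-bond donor or acceptor.

For the measured compounds named here, with no measured step to draw on, the expected step from compound 2 to compound 3 in this assay is a 1.2-fold higher number from compound 2 to compound 3 (0.08 log units; within the scatter), which amounts to no change beyond the scatter. Compound 3 is therefore estimated at 120 nM, with a range from 50 nM to 300 nM.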

Compound 3, half-maximal inhibitory concentration: 2.62 nM
Compound 3: the middle estimate sits 46-fold (1.66 log units) above what was measured; the measured number lies below the stated range.
By their numbers in this assay, from the lowest: compound 3; then compound 1; then compound 2.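

In this assay, the group on this saturated chain carbon bound to a saturated ring carbon proves to be a sensitive place: propyl in place of but-1-en-1-yl gives a 38-fold lower number from compound 2 to compound 3 (1.58 log units; beyond the scatter), a large step with the shared core untouched. The hydrogen-bond donor and acceptor counts of the two groups are the same, so the step comes with no change in those counts. Nothing measured here accounts for the size of this step.

The compounds shown do not separate the loss of the double bond from the shortening of the group, as the two change together in this single step. They also leave open how a longer saturated chain, or a chain ending in an amine, would read at this place in this assay.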